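Replacing a thiophene ring with a methoxyphenyl group

This account rests on a few compounds, and the source may have more. Where it says the series, first, only, none or still open, it means among the compounds named here.

Going by the values given here, compound 1 `O=C(N/N=C/c1cccs1)c1ccc(-c2nc3ccccc3s2)cc1` was tested in an assay on isolated protein for inhibition of Maltase-glucoamylase (Homo sapiens), with a stated time of 15 min (a lower number here means a stronger inhibitor, a higher number a weaker inhibitor), where compound 1 gives 8480 nM, the lowest of the three numbers measured so far. Compound 2 `O=C(N/N=C/c1ccc(O)c(O)c1)c1ccc(-c2nc3ccccc3s2)cc1` gives 15100 nM and compound 3 `O=C(N/N=C/c1ccc(F)c(Br)c1)c1ccc(-c2nc3ccccc3s2)cc1` gives 28000 nM. Compound 4 `COc1cccc(/C=N/NC(=O)c2ccc(-c3nc4ccccc4s3)cc2)c1` has not yet been measured; it differs from compound 1 in a single place: 3-methoxyphenyl in place of thiophen-2-yl on a carbon with a double bond to nitrogen. Two measured steps are comparable, since each also swaps the same thiophen-2-yl for a substituted six-membered ring: a 1.8-fold higher number from compound 1 to compound 2 (0.25 log units; within the scatter) and a 3.3-fold higher number from compound 1 to compound 3 (0.52 log units; beyond the scatter). Both moved the number upward, once within the scatter and once modestly beyond it. For compound 4 a similar modest upward shift is expected, a 1.8-fold higher number from compound 1 to compound 4 (0.25 log units; within the scatter). Compound 4 is therefore estimated at 15000 nM, with a range from 7000 nM to 35000 nM.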

Compound 4, half-maximal inhibitory concentration: 11100 nM
The estimate for compound 4 lay 1.4-fold (0.13 log units) above the measured number; the range from low to high includes it.
By their numbers in this assay, from the lowest: compounds 1, 4, 2 and 3 (each within the scatter of the next, the first and the last beyond it).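

In this assay the swap gives a 1.3-fold higher number from compound 1 to compound 4 (0.12 log units; within the scatter) and so shows that thiophen-2-yl can give way to a six-membered ring of carbon only, with more heavy atoms, and stay within the scatter. Changing what that ring carries gives a 2.5-fold lower number from compound 3 to compound 4 (0.40 log units; beyond the scatter) and a 1.4-fold lower number from compound 2 to compound 4 (0.13 log units; within the scatter) as well, the first beyond the scatter and the second within it. A six-membered ring here therefore does not by itself move the number beyond the scatter, although compound 3 shows that a particular pair of substituents can. On these data alone, how an amine or a carboxylic acid on this ring would shift the number stays open. Nothing available explains these differences.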